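The source may report more compounds than this note shows. Statements on the series, on what has been measured and on what is new or still open speak of the compounds shown alone.

Compound 2 `N#Cc1ccc(-c2ccc(COCCCCCN3C[C@H](O)[C@@H](O)[C@H](O)[C@H]3CO)cc2)cc1` belongs to a small set of three iminosugar-type compounds sharing one core and differing only in the terminal aryl group. In an assay on isolated protein for inhibition of ceramide glucosyltransferase (Homo sapiens) (on this read-out higher numbers stand for weaker inhibition and lower numbers for stronger inhibition), compound 2 gives 150 nM, the highest of the three numbers. Compound 1 `Cc1cccc(-c2ccc(COCCCCCN3C[C@H](O)[C@@H](O)[C@H](O)[C@H]3CO)cc2)c1` gives 100 nM, and compound 3 `OC[C@@H]1[C@@H](O)[C@H](O)[C@@H](O)CN1CCCCCOCc1ccc(-c2cc(C(F)(F)F)cc(C(F)(F)F)c2)cc1` gives 20 nM, so compound 2 stands nearest compound 1 and furthest from compound 3. Going by the values given here, the only single-point step among the measured compounds, a 1.5-fold higher number from compound 1 to compound 2 (0.18 log units; within the scatter), is within the scatter.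

Compound 4 `OC[C@@H]1[C@@H](O)[C@H](O)[C@@H](O)CN1CCCCCOCc1ccc(-c2ccc3c(c2)OCCO3)cc1` arises from compound 2 by 2,3-dihydro-1,4-benzodioxin-6-yl in place of 4-cyanophenyl on an aromatic carbon. Among the compounds with values here, the one step that bears on this change was within the scatter, while the pair compound 2 and compound 3 shows that an aryl change can move this read-out beyond it. Compound 4 is therefore expected to show no step beyond the scatter, a 1.4-fold lower number from compound 2 to compound 4 (0.13 log units; within the scatter), so for compound 4 a value of about 110 nM is estimated, between 40 nM and 300 nM.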

Compound 4, half-maximal inhibitory concentration: 40 nM
Compound 4: the middle estimate sits 2.8-fold (0.44 log units) above what was measured; low and high end bracket the measured number.
By their numbers in this assay, from the lowest: compounds 3 and 4 (each within the scatter of the next); then compounds 1 and 2 (each within the scatter of the next).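

Unlike the one earlier step, the change at this aromatic carbon in this assay moves the number beyond the scatter, with a 3.8-fold lower number from compound 2 to compound 4 (0.57 log units; beyond the scatter) for the replacement of 4-cyanophenyl. Against 3-methylphenyl the 2,3-dihydro-1,4-benzodioxin-6-yl group also gives a lower number, with a 2.5-fold lower number from compound 1 to compound 4 (0.40 log units; beyond the scatter), so it holds against both aryl groups compared in one place. Nothing given here accounts for these steps.

From the compounds shown here alone, it remains open whether the non-aromatic ring is needed, which a 3,4-dimethoxyphenyl group at this place would address. Going by these compounds, how an amine or a carboxylic acid on the terminal ring would read also remains open.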